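Series notes: biphenyl acetal in place of the nitrophenyl one

The source may report more compounds than this note shows. Statements on the series, on what has been measured and on what is new or still open speak of the compounds shown alone.

Measured so far:
compound 1, `CO[C@@H]1[C@@H](OC)[C@H](c2ccccc2)O[C@@H]2CO[C@@H](C3CCCCC3)O[C@@H]12`, 20 ug/mL
compound 2, `CO[C@@H]1[C@@H](OC)[C@H](c2ccccc2)O[C@@H]2CO[C@@H](c3ccc([N+](=O)[O-])cc3)O[C@@H]12`, "not determined" (no result reported)

In a functional assay on HEL cells (Homo sapiens) for cytotoxicity (a higher number here means that more compound is tolerated, a lower number that less compound is tolerated), compound 1 gives 20 ug/mL. Within the data shown here, for compound 2, `CO[C@@H]1[C@@H](OC)[C@H](c2ccccc2)O[C@@H]2CO[C@@H](c3ccc([N+](=O)[O-])cc3)O[C@@H]12`, the result in this assay is "not determined" (no result reported), so compound 2 stands on no single number and no step from it can be measured. Compound 3, `CO[C@@H]1[C@@H](OC)[C@H](c2ccccc2)O[C@@H]2CO[C@@H](c3ccc(-c4ccccc4)cc3)O[C@@H]12`, differs from compound 2 by phenyl in place of nitro on an aromatic carbon. Among the measured compounds shown here, with no step in this assay from compound 2 available, no direction or size beyond the scatter is claimed for the change. Compound 3 is expected to give about 20 ug/mL in this assay, within 5 ug/mL to 60 ug/mL.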

Compound 3, minimum cytotoxic concentration: >= 16 ug/mL
Compound 3 was reported as a limit (the forecaster's own chance of this, stated with the estimate: 25%); the middle value is on the limit's open side.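

No step can be read from compound 2 to compound 3 in this assay: compound 2 has no reported number. Compound 3 is recorded only as a limit, >= 16 ug/mL. The compounds shown leave open whether phenyl in place of nitro changes the result at all.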